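The compounds below may be only part of what the source reports. "The series", "measured", "known", "first", "only" and "open" are said of these compounds alone.

Compound 3 `Cc1cccc(C(=O)Nc2ccc3c(c2)CC(NS(=O)(=O)c2ccccc2)C3)c1-c1ccc(Cl)cc1` is the chloro member of the trio; in an assay for inhibition of apolipoprotein B-100 (Homo sapiens), tested at 100 nM (a higher number here means a weaker inhibitor, a lower number a stronger inhibitor), compound 3 gives 2.4 nM. Compound 1 `Cc1ccc(-c2c(C)cccc2C(=O)Nc2ccc3c(c2)CC(NS(=O)(=O)c2ccccc2)C3)cc1` gives 2.5 nM in this assay, and compound 2 `Cc1cccc(C(=O)Nc2ccc3c(c2)CC(NS(=O)(=O)c2ccccc2)C3)c1-c1ccc(C#N)cc1` gives 5.5 nM. The step of a 1.0-fold lower number from compound 1 to compound 3 (0.02 log units; within the scatter) lies within the scatter, whereas a 2.2-fold higher number from compound 1 to compound 2 (0.34 log units; beyond the scatter) and a 2.3-fold lower number from compound 2 to compound 3 (0.36 log units; beyond the scatter) lie beyond it, so compound 3 holds the lowest number of the three without being separated from compound 1.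

Compound 4 `COC(=O)NCC1Cc2ccc(NC(=O)c3cccc(C)c3-c3ccc(Cl)cc3)cc2C1` differs from compound 3 on the other side of the shared core: ((methoxycarbonyl)amino)methyl in place of (phenylsulfonyl)amino on a saturated ring carbon. None of the three measured steps bears on this change; each of them swaps a substituent on an aromatic carbon and leaves the (phenylsulfonyl)amino group in place. The size and direction of the step to compound 4 in this assay cannot be read from any measured pair, and the expectation rests only on the narrow band spanned by compounds 1 to 3. The step for compound 4 is expected at a 4.2-fold higher number from compound 3 to compound 4 (0.62 log units; beyond the scatter), with a wide margin. Compound 4 is accordingly estimated at 10 nM, within a range of 2 nM to 60 nM.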

Compound 4, half-maximal inhibitory concentration: 8.7 nM
Beside the measured number, compound 4's estimate is 1.1-fold (0.06 log units) above it, and the stated range covers the measured number.
By their numbers in this assay, from the lowest: compounds 3 and 1 (each within the scatter of the next); then compounds 2 and 4 (each within the scatter of the next).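

For the compounds shown here, the saturated ring carbon is the first site varied away from the aromatic substituents, and in this assay ((methoxycarbonyl)amino)methyl in place of (phenylsulfonyl)amino gives a 3.6-fold higher number from compound 3 to compound 4 (0.56 log units; beyond the scatter). The change is modest and lies beyond the scatter, and compound 4 remains at 8.7 nM with a smaller group that has no ring and the same hydrogen-bond donor and acceptor counts. No supporting data accompany this result, and the step stands unexplained. 

A single replacement does not separate the loss of (phenylsulfonyl)amino from the entry of ((methoxycarbonyl)amino)methyl, and an amine such as aminomethyl or a longer chain on that saturated ring carbon would bear on this. On these data alone, whether the aromatic-carbon steps among methyl, cyano and chloro carry over with ((methoxycarbonyl)amino)methyl in place also remains open.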